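Series notes: from compound 2 to compound 4

The source may report more compounds than this note shows. Statements on the series, on what has been measured and on what is new or still open speak of the compounds shown alone.

Measured so far:
compound 1 `CCCN(c1ccccc1)S(=O)(=O)c1ccc(N2CCCC2=O)cc1`, > 5000 nM
compound 2 `CN1CCN(S(=O)(=O)c2ccc(N3CCCC3=O)cc2)c2ccccc21`, 10 nM
compound 3 `O=S(=O)(c1ccc(-n2cncn2)cc1)N1CCCc2ccccc21`, > 5000 nM

The read-out throughout is a functional assay on MCF7 cells (Homo sapiens) for antiproliferative activity, read by fluorescence and SYBR Green assay, with a stated time of 24 h; on this read-out higher numbers stand for weaker inhibition and lower numbers for stronger inhibition. For the measured compounds named here, compound 2 is the only member with a number: in this assay compound 2 gives 10 nM. For compound 1 the assay reports only a limit, > 5000 nM. For compound 3 the assay likewise reports only a limit, > 5000 nM. Going by the values given here, two of the three results thus sit at the limit of > 5000 nM in this assay, at which 2 of the 3 values shown sit, so compound 2 stands alone as the one active point, and no step between measured compounds can be computed.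

Compound 4 `CN1CCN(S(=O)(=O)c2ccc(N3CCCC3)cc2)c2ccccc21` is not yet measured. It differs from compound 2 in one place: pyrrolidin-1-yl in place of 2-oxopyrrolidin-1-yl on an aromatic carbon. The carbonyl of the five-membered ring is gone; the rest of the molecule is unchanged.

Among the compounds with values here, no measured pair speaks to this change, so the direction is open. The working expectation is a loss of potency beyond the usual scatter, with the step from compound 2 to compound 4 estimated as a 15-fold higher number from compound 2 to compound 4 (1.18 log units; beyond the scatter). On that basis compound 4 is expected to give about 150 nM in this assay, with a range from 15 nM to 3000 nM.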

Compound 4, half-maximal inhibitory concentration: 4 nM
Compound 4: middle estimate off by 38-fold (1.57 log units), on the high side, and the stated range ends above it.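

In this assay, pyrrolidin-1-yl in place of 2-oxopyrrolidin-1-yl on an aromatic carbon, para to a large group, gives a 2.5-fold lower number from compound 2 to compound 4 (0.40 log units; beyond the scatter), a modest gain that lies beyond the scatter. Compound 2 therefore no longer stands alone as the only active point, and this position is shown to keep a low number on the shared core without the carbonyl of the five-membered ring. Nothing in the data bears on why the loss of that carbonyl gives this step.

For the compounds shown here, compound 1 and compound 3 carry only limits of the assay, and no step involving either of them can be read, so the one measured change at this position rests on a single pair. How far this position tolerates other groups stays open: an open-chain dimethylamino group, a six-membered morpholin-4-yl ring or a carboxylic acid in the same place could each move the number in either direction, and the compounds shown do not say whether the step from the 2-oxopyrrolidin-1-yl group would carry over to another core.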